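Swapping cyclohexyl for 2-cyclohexylethyl on a carbonyl carbon

The compounds below may be only part of what the source reports. "The series", "measured", "known", "first", "only" and "open" are said of these compounds alone.

Measured so far in an ADME assay on HepG2 2.2.15 cells (Homo sapiens) for cytotoxicity; a higher number here means that more compound is tolerated, a lower number that less compound is tolerated
Compound 1 `O=C(O)CCCC(=O)OCCc1c(-c2ccccc2Cl)c2cc(Cl)ccc2[nH]c1=O` gives 110000 nM
Compound 2 `CCOCC(=O)OCCc1c(-c2ccccc2Cl)c2cc(Cl)ccc2[nH]c1=O` gives 130000 nM
Compound 3 `O=C(OCCc1c(-c2ccccc2Cl)c2cc(Cl)ccc2[nH]c1=O)C1CCCCC1` gives 38000 nM

These three compounds share one core and differ only in the group on the carbonyl carbon. Compound 3 has the lowest number of the three, which means that the least of it is tolerated. The other two cannot be told apart (a 1.2-fold higher number from compound 1 to compound 2 (0.07 log units; within the scatter)).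

Compound 4 `O=C(CCC1CCCCC1)OCCc1c(-c2ccccc2Cl)c2cc(Cl)ccc2[nH]c1=O` has not been measured yet. It carries 2-cyclohexylethyl in place of cyclohexyl on a carbonyl carbon.

Going by the values given here, two measured steps bear on this change. Cyclohexyl in place of 3-carboxypropyl gave a modest drop (a 2.9-fold lower number from compound 1 to compound 3 (0.46 log units; beyond the scatter)), and cyclohexyl in place of ethoxymethyl gave a similar one (a 3.4-fold lower number from compound 2 to compound 3 (0.53 log units; beyond the scatter)). Neither step lengthens a chain that ends in the ring, so the data offer only indirect guidance. The entering group still holds the six-membered non-aromatic ring of carbon only, so compound 4 is expected to stay near compound 3 (38000 nM). The expected step is small and downward, and smaller than those two (a 1.4-fold lower number from compound 3 to compound 4 (0.15 log units; within the scatter)). In this assay compound 4 is estimated at 27000 nM (expected range 11000 nM to 60000 nM).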

Compound 4, half-maximal cytotoxic concentration: 160000 nM
Compound 4: middle estimate off by 5.9-fold (0.77 log units), on the low side, and the stated range ends below it.
By their numbers in this assay, from the lowest: compound 3; then compounds 1, 2 and 4 (each within the scatter of the next).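

In this assay, going from cyclohexyl to 2-cyclohexylethyl on a carbonyl carbon moves the number up rather than leaving it near compound 3 (a 4.2-fold higher number from compound 3 to compound 4 (0.62 log units; beyond the scatter)), so more of the longer-chained compound is tolerated even though the same six-membered carbon ring is still present. Compound 4 cannot be told apart from the compounds with the ethoxymethyl group (a 1.2-fold higher number from compound 2 to compound 4 (0.09 log units; within the scatter)) or the 3-carboxypropyl group (a 1.5-fold higher number from compound 1 to compound 4 (0.16 log units; within the scatter)), which leaves compound 3 as the only one of the four with a clearly lower number. The ring attached through the 2-ethyl chain and the ring attached directly to the carbonyl carbon give different numbers. Nothing available here explains this difference.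

These four compounds cannot show whether the number keeps rising, levels off or falls when a longer chain ends in the cyclohexyl ring. From the compounds shown here alone, it also remains open what an amine or a phenyl ring at the end of the 2-ethyl chain would do in this assay.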